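Swapping a dichlorophenyl thioether for a fluorophenoxy group

The source may report more compounds than this note shows. Statements on the series, on what has been measured and on what is new or still open speak of the compounds shown alone.

Three compounds sharing one core have been examined in a functional assay on SK-MEL-2 cells (Homo sapiens) for inhibition, read by sulforhodamine B assay, with a stated time of 48 h; on this read-out higher numbers stand for weaker inhibition of growth and lower numbers for stronger inhibition of growth. Compound 1 `Nc1cc(N)c2nc(-c3ccccc3)c(Oc3ccc(Cl)c(Cl)c3)nc2c1` gives 23400 nM. Compound 3 `Nc1cc(N)c2nc(-c3ccccc3)c(Sc3ccc(Cl)c(Cl)c3)nc2c1` gives 30900 nM, the highest of the two numbers on record, with compound 1 as its nearest neighbour through a 1.3-fold higher number from compound 1 to compound 3 (0.12 log units; within the scatter). Compound 2 `COc1ccc(Sc2nc3cc(N)cc(N)c3nc2-c2ccccc2)cc1` returns only a limit of the assay, < 100000 nM, as noted in the limit of < 100000 nM in this assay, at which 1 of the 3 values shown sits; the steps a step that the limit leaves unreadable from compound 1 to compound 2 and a step that the limit leaves unreadable from compound 2 to compound 3 therefore cannot be sized.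

The next compound is compound 4 `Nc1cc(N)c2nc(-c3ccccc3)c(Oc3ccc(F)cc3)nc2c1`. It differs from compound 3 by 4-fluorophenoxy in place of (3,4-dichlorophenyl)sulfanyl on an aromatic carbon. For the measured compounds named here, only one measured step touches this change: the exchange of oxygen for sulfur between compound 1 and compound 3, which stayed within the scatter. Going by the values given here, no measured step covers the move from a 3,4-dichlorophenyl group to a 4-fluorophenyl group, since the one comparison involving a different aryl group, compound 2, ends at a limit.

On this basis compound 4 is expected to sit near compound 3, with a 1.0-fold lower number from compound 3 to compound 4 (0.01 log units; within the scatter) as the estimated step, not clearly beyond the scatter in either direction. The estimate for compound 4 in this assay is 30000 nM, within a range from 9000 nM to 100000 nM.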

Compound 4, concentration for total growth inhibition: < 100000 nM
Compound 4 ended at the assay's limit; the forecaster's own chance of this, stated with the estimate: 20%; the middle value does not contradict the limit.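

In this assay compound 4 returns only a limit of the assay, given as < 100000 nM and no number, so no step from compound 1, compound 2 or compound 3 to compound 4 can be read: the limit of < 100000 nM in this assay, at which 2 of the 4 values shown sit.

In this assay the compounds shown leave open whether 4-fluorophenyl in place of 3,4-dichlorophenyl on the oxygen changes the number at all.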